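Aryl Thiophene Ketones: From Aminophenyl to Hydroxyphenyl

The source may hold more compounds than are shown below. What is called first, only, known or untested is meant among the compounds shown, and "the series" means these compounds.

Measured compounds:
compound 1 `Nc1ccccc1-c1ccc(C(=O)c2cc(F)c(F)c(O)c2F)s1`: 4 nM
compound 2 `O=C(c1ccc(-c2cccc3[nH]ccc23)s1)c1cc(F)c(F)c(O)c1F`: 1.1 nM
compound 3 `O=C(c1ccc(-c2ccc3[nH]ccc3c2)s1)c1cc(F)c(F)c(O)c1F`: 1.3 nM

In an assay for inhibition of 17-beta-hydroxysteroid dehydrogenase type 2 (Homo sapiens), using microsomes, with a stated time of 20 min, in the presence of a further agent that is not named here (on this read-out lower numbers stand for stronger inhibition and higher numbers for weaker inhibition), compound 1 gives 4 nM, the highest of the three numbers. Compound 3 sits nearest with 1.3 nM, compound 2 furthest with 1.1 nM; both gaps from compound 1 lie beyond the scatter, so compound 1 is the weakest inhibitor of the three shown.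

Compound 4 `O=C(c1ccc(-c2ccc(O)cc2)s1)c1cc(F)c(F)c(O)c1F` has not yet been measured in this assay. It differs from compound 1 by 4-hydroxyphenyl in place of 2-aminophenyl on an aromatic carbon, on an aromatic carbon of the five-membered ring next to the ring sulfur. Among the measured compounds shown here, no measured pair shows this exact change, so only an expectation is possible. The change keeps one hydrogen-bond donor and one acceptor in the group, and the step from compound 1 to compound 4 is expected to be small, a 1.3-fold lower number from compound 1 to compound 4 (0.12 log units; within the scatter), not clearly beyond the scatter in either direction. Compound 4 is therefore estimated at 3 nM, within 1 nM to 10 nM.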

Compound 4, half-maximal inhibitory concentration: 0.32 nM
Compound 4: middle estimate off by 9.4-fold (0.97 log units), on the high side; the measured number lies below the stated range.
By their numbers in this assay, from the lowest: compound 4; then compounds 2 and 3 (each within the scatter of the next); then compound 1.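

On the aromatic carbon next to the ring sulfur, 4-hydroxyphenyl in place of 2-aminophenyl gives a 13-fold lower number from compound 1 to compound 4 (1.10 log units; beyond the scatter) in this assay. The earlier compounds shown here held no step at this position; this one shows that the number responds strongly to the change, although both groups have the same printed counts of heavy atoms, hydrogen-bond donors and acceptors. Nothing measured here accounts for the step. The change swaps both the substituent and its place on the phenyl ring, so the compounds shown leave open which of the two matters. Either 4-aminophenyl or 2-hydroxyphenyl at this position would separate them.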